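Notes on compound 4 against the three measured ethers

The source may hold more compounds than are shown below. What is called first, only, known or untested is meant among the compounds shown, and "the series" means these compounds.

Among the measured compounds shown here, compound 1 `COc1cc(OC)c(-c2coc3cc(OCc4ccccc4F)ccc3c2=O)cc1OC` gives 1610 nM in a functional assay on B16 cells (Mus musculus) for antiproliferative activity, read by MTT assay, with a stated time of 24 h (on this read-out lower numbers stand for stronger inhibition and higher numbers for weaker inhibition), the lowest of the three numbers measured so far, though the other two lie within the scatter of it. Compound 2 `COc1cc(OC)c(-c2coc3cc(OCc4ccccc4C#N)ccc3c2=O)cc1OC` gives 2140 nM, a step of a 1.3-fold higher number from compound 1 to compound 2 (0.12 log units; within the scatter). Compound 3 `COc1cc(OC)c(-c2coc3cc(OCc4cccc(F)c4)ccc3c2=O)cc1OC` gives 2440 nM, a step of a 1.5-fold higher number from compound 1 to compound 3 (0.18 log units; within the scatter); from compound 2 the step is a 1.1-fold higher number from compound 2 to compound 3 (0.06 log units; within the scatter). Compound 4 `COc1cc(OC)c(-c2coc3cc(OCc4cccc(Cl)c4)ccc3c2=O)cc1OC` is unmeasured; it differs from compound 1 by 3-chlorophenyl in place of 2-fluorophenyl on a saturated chain carbon bound to an oxygen on an aromatic ring. The step from compound 1 to compound 3, which already puts 3-fluorophenyl in place of 2-fluorophenyl, bears most on it and stayed within the scatter. For the measured compounds named here, no measured step covers chlorine in place of fluorine. Compound 4 is therefore expected close to compound 1, with a 1.4-fold higher number from compound 1 to compound 4 (0.14 log units; within the scatter), estimated at 2200 nM in the range 1100 nM to 4500 nM.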

Compound 4, half-maximal inhibitory concentration: 2280 nM
Estimate against measurement, compound 4: 1.0-fold (0.02 log units) below, within the range that was stated.
By their numbers in this assay, from the lowest: compounds 1, 2, 4 and 3 (each within the scatter of the next).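

In this assay, replacing the fluorine by a chlorine is now covered by a measured step and stays within the scatter (a 1.1-fold lower number from compound 3 to compound 4 (0.03 log units; within the scatter)). With 3-chlorophenyl on the saturated chain carbon bound to an oxygen on an aromatic ring, the number also stays within the scatter of the 2-fluorophenyl and 2-cyanophenyl ethers (a 1.4-fold higher number from compound 1 to compound 4 (0.15 log units; within the scatter); a 1.1-fold higher number from compound 2 to compound 4 (0.03 log units; within the scatter)), so these four ethers remain unresolved from one another. Nothing available explains this flat result. Still open, as far as these compounds go, is whether an amine, a carboxylic acid or a longer chain in place of the substituted phenyl would give a step beyond the scatter.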